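The source may hold more compounds than are shown below. What is called first, only, known or untested is meant among the compounds shown, and "the series" means these compounds.

Measured so far:

Compound 1, `Cc1ccccc1NC(=O)N[C@@H](C)c1ccccc1`, gives 100% in an ADME assay on the whole organism with Oryza sativa as the target, tested at 0.1 uM; on this read-out higher numbers stand for a weaker effect at the one concentration tested and lower numbers for a stronger effect.
Compound 2, `C[C@H](NC(=O)Nc1ccccc1C(C)(C)C)c1ccccc1`, gives 101% in this assay.
Compound 3, `CC(=O)c1ccccc1NC(=O)N[C@@H](C)c1ccccc1`, gives 100% in this assay.

Compound 3 stands level with compound 1 at the digits reported, and together these two are the lowest of the three numbers; its nearest neighbour is compound 1, with no change at the digits printed from compound 1 to compound 3 (within the scatter), and its furthest is compound 2, with a number 1 percentage points lower from compound 2 to compound 3 (within the scatter), so all three readings sit within the usual scatter of one another, each close to full activity remaining at the single concentration tested.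

The next compound, compound 4, `C[C@H](NC(=O)Nc1ccccc1Cl)c1ccccc1`, keeps the shared core of compound 3 and differs in one place: chloro in place of acetyl on an aromatic carbon. Among the compounds with values here, the steps that bear on this change are those that alter the same aromatic carbon, no change at the digits printed from compound 1 to compound 3 (within the scatter) and a number 1 percentage points lower from compound 2 to compound 3 (within the scatter), and also a number 1 percentage points higher from compound 1 to compound 2 (within the scatter); none of them moved the read-out beyond the scatter. On this basis the step from compound 3 to compound 4 is expected to be no change at the digits printed from compound 3 to compound 4 (within the scatter), with no direction beyond the scatter. For compound 4 the estimated value in this assay is 100%, with an expected range from 92% to 108%.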

Compound 4, a percentage reported as activity, at one concentration (the size of the read-out at that concentration, not a potency): 99%
Estimate against measurement, compound 4: 1 percentage points above, and the stated range covers the measured number.
By their numbers in this assay, from the lowest: compounds 4, 1, 3 and 2 (each within the scatter of the next).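

In this assay chloro now joins methyl, tert-butyl and acetyl on this aromatic carbon, ortho to a large group, and every step to it stays within the scatter (a number 1 percentage points lower from compound 3 to compound 4 (within the scatter); a number 2 percentage points lower from compound 2 to compound 4 (within the scatter); a number 1 percentage points lower from compound 1 to compound 4 (within the scatter)). The new step swaps acetyl, with 3 heavy atoms, 1 double bond and 1 hydrogen-bond acceptor, for chloro, with 1 heavy atom and 0 hydrogen-bond acceptors, so a halogen and a group carrying a carbonyl read alike here, as do the two groups attached through carbon, methyl and tert-butyl. Nothing available accounts for this flat picture across the four compounds.

From the compounds shown here alone, what an amine, a carboxylic acid or a longer chain would do on this same aromatic carbon remains open, and so does whether any group at this place can move the read-out beyond the scatter. Also open, going by these compounds, is whether these four compounds would still read alike at another concentration, and whether a change elsewhere on the shared core would separate them.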